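From Acetyl to Methoxycarbonyl on a Shared Core

This account rests on a few compounds, and the source may have more. Where it says the series, first, only, none or still open, it means among the compounds named here.

In an ADME assay on BJ cells (Homo sapiens) for cytotoxicity, with a stated time of 72 h (on this read-out higher numbers stand for an effect only at larger amounts of compound and lower numbers for an effect already at smaller amounts), compound 1 `CC(=O)c1ccc(NC(=O)Nc2cc(C)nc3ccccc23)cc1` gives 22000 nM and compound 2 `COc1ccc(NC(=O)Nc2cc(C)nc3ccccc23)cc1Cl` gives 23000 nM so the two values lie within the usual scatter of each other. Compound 3 `COC(=O)c1ccc(NC(=O)Nc2cc(C)nc3ccccc23)cc1` has not been measured yet. It carries methoxy in place of methyl on a carbonyl carbon which turns acetyl to methoxycarbonyl. For the measured compounds named here, no measured pair shows this change, so the step expected in this assay is none beyond the scatter. The estimate is no change at the digits printed from compound 1 to compound 3 (within the scatter) with no clear direction. Compound 3 is expected at 22000 nM with an estimated range from 11000 nM to 45000 nM when measured.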

Compound 3, half-maximal effective concentration: 21000 nM
Compound 3: middle estimate off by 1.0-fold (0.02 log units), on the high side; measured number inside the range.
By their numbers in this assay, from the lowest: compounds 3, 1 and 2 (each within the scatter of the next).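

Methoxy in place of methyl on a carbonyl carbon gives a 1.0-fold lower number from compound 1 to compound 3 (0.02 log units; within the scatter) and so in this assay acetyl and methoxycarbonyl cannot be told apart at this position. For the compounds shown here, this is the first step here between compounds that differ in one place, something the earlier pair could not offer. Nothing at hand explains this result.

From the compounds shown here alone, it remains open whether a carboxylic acid or a primary amide at this position would stay within the scatter of compound 1. The same question holds for a longer chain, such as ethoxy in place of methoxy.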